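A few compounds are considered here, and "the series" means these few. Any claim that something is new, unique, unknown or untested is made for them only; others in the source may bear on it.

Measured so far:
- compound 1 `O=C1CC(c2nc(Cc3ccccc3)no2)CN1c1ccc(F)cc1`, 23000 nM
- compound 2 `O=C1CC(c2nc(-c3cccc(Cl)c3)no2)CN1Cc1ccc(F)cc1`, 23000 nM

In a physicochemical assay for solubility, read by HPLC (a lower number here means a less soluble compound, a higher number a more soluble compound), compound 1 gives 23000 nM, and compound 2 gives 23000 nM. The two values are the same at the digits shown, so compound 1 stands level with compound 2 in this assay, and nothing separates them beyond the scatter.

Compound 3 `Cc1cccc(-c2noc(C3CC(=O)N(c4ccc(F)cc4)C3)n2)n1` is not yet measured. It differs from compound 1 in one place: 6-methylpyridin-2-yl in place of benzyl on an aromatic carbon. Among the compounds with values here, no step between measured compounds covers this kind of change, so the size of the step has to be guessed from the structures alone. The group that enters has the same heavy-atom count as the one that leaves and brings one hydrogen-bond acceptor, so a modest rise in solubility, or no change beyond the scatter, is expected. For compound 3 the expected value is 32000 nM, with a range from 11000 nM to 95000 nM, which means an estimated step of a 1.4-fold higher number from compound 1 to compound 3 (0.14 log units; within the scatter).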

Compound 3, solubility: 26000 nM
For compound 3 the middle estimate is 1.2-fold (0.09 log units) above the measured one; low and high end bracket the measured number.
By their numbers in this assay, from the lowest: compounds 1, 2 and 3 (each within the scatter of the next).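

In this assay the exchange of benzyl for 6-methylpyridin-2-yl, on an aromatic carbon of the five-membered aromatic ring, gives a 1.1-fold higher number from compound 1 to compound 3 (0.05 log units; within the scatter) and so leaves the two compounds indistinguishable by this read-out. Within the data shown here, this is the first comparison here that changes only one place: the entering group has the same heavy-atom count as the one that leaves and adds a hydrogen-bond acceptor, and that exchange alone produces no readable change in this pair. Nothing measured here offers a reason for this result.

One pair cannot show whether the same holds for other groups at this position. A plain pyridin-2-yl without the methyl, or a group carrying an amine or a carboxylic acid, remains an open case, and its effect on the number cannot be told from these compounds.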